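The compounds below may be only part of what the source reports. "The series", "measured", "known", "first", "only" and "open" are said of these compounds alone.

Measured so far in an assay on isolated protein for inhibition of Rho-associated protein kinase 1 (Homo sapiens), read by scintillation counting, radiometric assay and 33P incorporation, with a stated time of 40 min, in the presence of a further agent that is not named here; a higher number here means a weaker inhibitor, a lower number a stronger inhibitor: compound 1 `O=C(COc1ccc2c(=O)ccoc2c1)Nc1cccc(NC(=O)c2ccccc2)c1` gives 120 nM; compound 2 `CCOc1ccc(C(=O)Nc2cccc(NC(=O)COc3ccc4c(=O)ccoc4c3)c2)cc1` gives 17 nM; compound 3 `O=C(COc1ccc2c(=O)ccoc2c1)Nc1cccc(NC(=O)c2ccc(OC(F)(F)F)cc2)c1` gives 869 nM.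

Compound 3 stands highest of the three numbers, above compound 1 by a 7.2-fold higher number from compound 1 to compound 3 (0.86 log units; beyond the scatter) and above compound 2 by a 51-fold higher number from compound 2 to compound 3 (1.71 log units; beyond the scatter). The step to compound 4 `Cc1cc(C(=O)Nc2cccc(NC(=O)COc3ccc4c(=O)ccoc4c3)c2)no1` is 5-methyl-1,2-oxazol-3-yl in place of 4-(trifluoromethoxy)phenyl on a carbonyl carbon. Among the measured compounds shown here, no measured step exchanges this ring as a whole; the three steps only vary a substituent on it, including a 7.1-fold lower number from compound 1 to compound 2 (0.85 log units; beyond the scatter), so a ring replacement is weakly informed. Because a 7.2-fold higher number from compound 1 to compound 3 (0.86 log units; beyond the scatter) accompanied the arrival of the trifluoromethoxy, its departure is expected to lower the number, with the new ring adding uncertainty. Compound 4 is therefore estimated at 200 nM, within 40 nM to 1000 nM, an expected step of a 4.3-fold lower number from compound 3 to compound 4 (0.64 log units; beyond the scatter).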

Compound 4, half-maximal inhibitory concentration: 68 nM
The estimate for compound 4 lay 2.9-fold (0.47 log units) above the measured number; measured number inside the range.
By their numbers in this assay, from the lowest: compound 2; then compounds 4 and 1 (each within the scatter of the next); then compound 3.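

Exchanging the whole ring on the carbonyl carbon, rather than a substituent on it, is compatible with inhibition in this assay: the smaller 5-methyl-1,2-oxazol-3-yl matches the unsubstituted phenyl, with a 1.8-fold lower number from compound 1 to compound 4 (0.25 log units; within the scatter). Against the substituted phenyls, the new ring gives a 13-fold lower number from compound 3 to compound 4 (1.11 log units; beyond the scatter) and a 4.0-fold higher number from compound 2 to compound 4 (0.60 log units; beyond the scatter). A phenyl is therefore not required at this position, although 4-ethoxyphenyl still gives the lowest number.

From the compounds shown here alone, whether a pyridine, a thiophene or an oxazole carrying an amine in place of the methyl would behave alike remains open. Nothing available here explains these differences.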